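The source may report more compounds than this note shows. Statements on the series, on what has been measured and on what is new or still open speak of the compounds shown alone.

Compound 1, `O=C1Nc2ccc(Br)cc2/C1=N/NC(=S)Nc1ccc(Cl)cc1`, gives 29000 nM in a functional assay on MOLT-4 cells (Homo sapiens), with a stated time of 72 h; a higher number here means a weaker inhibitor, a lower number a stronger inhibitor. Compound 2, `Cc1ccc(NC(=S)N/N=C2\C(=O)Nc3ccc(Br)cc32)cc1`, gives 4900 nM in this assay. Compound 3, `Cc1ccc(CN2C(=O)/C(=N\NC(=S)Nc3ccc(Cl)cc3)c3cc(Cl)ccc32)cc1`, gives 5800 nM in this assay.

Compounds 1 and 2 share a core and differ in one place, (chloro in place of methyl on an aromatic carbon). That change brought a 5.9-fold higher number from compound 2 to compound 1 (0.77 log units; beyond the scatter), so the chloro-bearing compound 1 is the weaker inhibitor of the pair. Compound 3 carries a different core from compound 2; how the two cores differ is not broken down here, and the two values of compound 2 and compound 3 lie within the scatter of each other.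

The unmeasured compound 4, `O=C1/C(=N\NC(=S)Nc2ccc(Cl)cc2)c2cc(Cl)ccc2N1Cc1ccc(Cl)cc1`, is made from compound 3 by chloro in place of methyl on an aromatic carbon. The place reads the same as in the step from compound 2 to compound 1, but read one bond further out the change in compound 3 is 4-methylbenzyl to 4-chlorobenzyl, so the group sits on another part of the molecule than in compound 2. Within the data shown here, because the only measured example of this change is a 5.9-fold higher number from compound 2 to compound 1 (0.77 log units; beyond the scatter), some weakening is expected for compound 4, though with a single example in a different part of the molecule the size is uncertain, and a smaller step than before is estimated: a 1.6-fold higher number from compound 3 to compound 4 (0.19 log units; within the scatter). Compound 4 is therefore expected at about 9000 nM, with a likely range from 3000 nM to 30000 nM.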

Compound 4, half-maximal inhibitory concentration: 58000 nM
The estimate for compound 4 lay 6.4-fold (0.81 log units) below the measured number; measured number above the stated range.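

In this assay, putting chloro in place of methyl on an aromatic carbon again goes with a weaker inhibitor, with a 10-fold higher number from compound 3 to compound 4 (1.00 log units; beyond the scatter). Set beside the earlier example, the change carries over from one core to the other in direction, and the two steps do not differ in size: the same change on two cores in this assay, a 5.9-fold higher number (0.77 log units; beyond the scatter) from compound 2 to compound 1 and a 10-fold higher number (1.00 log units; beyond the scatter) from compound 3 to compound 4, 1.7-fold (0.23 log units) apart, within the scatter of two such steps. This shows that the weakening held in both pairs, even though the change reads as 4-methylphenyl to 4-chlorophenyl in the first pair and as 4-methylbenzyl to 4-chlorobenzyl in the second, but two pairs are too few to make a rule for other cores in the series, and they do not show why the change weakens these compounds.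

The compounds shown leave open whether the weakening is particular to chloro or would also appear with other groups in the same place, such as fluoro, methoxy, trifluoromethyl or an amine, and how any of these would compare with plain hydrogen there. They also leave open whether the same step would appear on further cores, or with the methyl or chloro moved elsewhere on the aromatic ring.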